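The source may report more compounds than this note shows. Statements on the series, on what has been measured and on what is new or still open speak of the compounds shown alone.

In an assay on membranes from HEK293 cells for displacement of a labelled ligand from adenosine receptor A2b (Homo sapiens), read by scintillation counting, with a stated time of 30 min (on this read-out higher numbers stand for weaker inhibition and lower numbers for stronger inhibition), the measured compounds are: compound 1 `CCCOC(=O)C1=C(C)NC(=O)NC1c1ccsc1` with 201 nM; compound 2 `CC1=C(C(=O)CC(C)C)C(c2ccco2)NC(=O)N1` with 240 nM; compound 3 `CC1=C(C(=O)CC(C)C)C(c2ccoc2)NC(=O)N1` with 1010 nM.

Compound 3 thus gives the highest number of the three in this assay. Among the measured compounds shown here, the only single-place step measured, a 4.2-fold higher number from compound 2 to compound 3 (0.62 log units; beyond the scatter), does not match the exchange now at hand. Compound 4 `CC1=C(C(=O)CC(C)C)C(c2ccsc2)NC(=O)N1` differs from compound 3 by thiophen-3-yl in place of furan-3-yl on a saturated ring carbon. For the measured compounds named here, no measured pair shows this exchange on the shared core. Compound 1, which also carries thiophen-3-yl but on a different core, gives a lower number than compound 3 in this assay; this comparison spans two changes and so only loosely supports the expectation. Compound 4 is therefore expected to give 400 nM (range 150 nM to 1100 nM), an expected step of a 2.5-fold lower number from compound 3 to compound 4 (0.40 log units; beyond the scatter).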

Compound 4, inhibition constant: 1000 nM
Compound 4: middle estimate off by 2.5-fold (0.40 log units), on the low side; the measured number falls inside the stated range.
By their numbers in this assay, from the lowest: compounds 1 and 2 (each within the scatter of the next); then compounds 4 and 3 (each within the scatter of the next).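

In this assay the exchange of furan-3-yl for thiophen-3-yl on a saturated ring carbon gives a 1.0-fold lower number from compound 3 to compound 4 (0.00 log units; within the scatter) so the hetero atom of this ring makes no difference beyond the scatter here. Furan-2-yl remains the exception on the shared core, with a 4.2-fold higher number from compound 2 to compound 4 (0.62 log units; beyond the scatter) as the counterpart of a 4.2-fold higher number from compound 2 to compound 3 (0.62 log units; beyond the scatter) while, with thiophen-3-yl held constant, isobutyl in place of propoxy on a carbonyl carbon gives a 5.0-fold higher number from compound 1 to compound 4 (0.70 log units; beyond the scatter) and shows that this second site also matters. On these data alone, whether thiophen-2-yl or phenyl on the shared core would match furan-2-yl remains open. Nothing available explains these steps.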